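Swapping the Aryl Group on a Weak Porcupine Inhibitor

A few compounds are considered here, and "the series" means these few. Any claim that something is new, unique, unknown or untested is made for them only; others in the source may bear on it.

Compound 1 `COc1ccc2nc(NC(=O)CNC(=O)c3nn(-c4ccccc4OC)c(=O)c4ccccc34)sc2c1` in an assay on L cells for inhibition of Protein-serine O-palmitoleoyltransferase porcupine (Mus musculus), read by reporter gene assay, with a stated time of 24 h (on this read-out higher numbers stand for an effect only at larger amounts of compound and lower numbers for an effect already at smaller amounts), gives 90 nM. Compound 2 `COc1ccccc1-n1nc(C(=O)NCC(=O)Nc2nc3ccccc3s2)c2ccccc2c1=O` carries hydrogen where compound 1 has a methoxy group on an aromatic carbon; in this assay compound 2 gives 10000 nM, and the step of a 110-fold higher number from compound 1 to compound 2 (2.05 log units; beyond the scatter) is large. Compound 3 `CCOC(=O)c1ccc2nc(NC(=O)CNC(=O)c3nn(-c4ccccc4)c(=O)c4ccccc34)sc2c1` in this assay reaches only a limit, > 25000 nM. Compound 2 therefore stands at the highest of the two real numbers, while compound 3 is known only as a limit (the limit of > 25000 nM in this assay, at which 1 of the 3 values shown sits).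

Compound 4 `O=C(CNC(=O)c1nn(-c2ccc(F)cc2)c(=O)c2ccccc12)Nc1nc2ccccc2s1` differs from compound 2 by 4-fluorophenyl in place of 2-methoxyphenyl on an aromatic nitrogen. Going by the values given here, no measured step changes the group on that aromatic nitrogen, so the sole anchor is compound 2 itself. Compound 4 is thus expected to lie close to compound 2, a step of no change at the digits printed from compound 2 to compound 4 (within the scatter) within the scatter, with an estimated value of 10000 nM (range 2500 nM to 30000 nM).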

Compound 4, half-maximal effective concentration: > 25000 nM
Compound 4 ended at the assay's limit; the forecaster's own chance of this, stated with the estimate: 30%; middle value at least 2.5-fold (0.39 log units) from the limit.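

Going by these compounds alone, until now no step touched the group on this aromatic nitrogen, and in this assay it proves not to be neutral: 4-fluorophenyl in place of 2-methoxyphenyl gives an at least 2.5-fold higher number from compound 2 to compound 4 (0.39 log units; beyond the scatter). Compound 4 has only a limit, not a number, so this step gives a minimum size: the limit of > 25000 nM in this assay, at which 2 of the 4 values shown sit.

The change also removes the methoxy and adds a fluorine at once, so it cannot show which of the two counts. Open, on these data alone, is how an ethoxy group or a chlorine would fare in place of that methoxy, and whether the same swap would cost as much on compound 1, whose 90 nM leaves room for a real number.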